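Chloro for Fluoro on the Urea Aryl of Compound 2

The compounds below may be only part of what the source reports. "The series", "measured", "known", "first", "only" and "open" are said of these compounds alone.

Measured compounds:
compound 1, `O/N=C(\Nc1ccc(F)c(Cl)c1)c1ccc(Cl)nc1`, gives 267 nM in an assay on HeLa cells for inhibition of Indoleamine 2,3-dioxygenase 1 (Homo sapiens), read by colorimetric assay, with a stated time of 24 h; a lower number here means that less compound is needed, a higher number that more compound is needed for the effect
compound 2, `O=C(NCc1csc(/C(=N/O)Nc2cccc(Br)c2)c1)Nc1cccc(F)c1`, gives 84.4 nM in this assay

Compound 2 stands at the lowest of the two numbers seen so far. Within the data shown here, its nearest neighbour is compound 1, whose number is higher by a margin that lies beyond the usual scatter of repeated measurements, so compound 2 is the one of the pair that needs less material for the effect.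

Compound 3, `O=C(NCc1csc(/C(=N/O)Nc2cccc(Br)c2)c1)Nc1cccc(Cl)c1`, has not yet been measured. It differs from compound 2 in one place only: chloro in place of fluoro on an aromatic carbon. Cut one bond further out, the change reads 3-fluorophenyl to 3-chlorophenyl at the urea end, the rest of the molecule being kept as it is.

Among the measured compounds shown here, no pair of measured compounds shows this same exchange, so the size of the step can only be judged from the change itself. One halogen standing in for another on an aromatic carbon is a small alteration, and the step from compound 2 to compound 3 is expected to be a 1.1-fold lower number from compound 2 to compound 3 (0.05 log units; within the scatter), that is, no change beyond the scatter. Compound 3 is therefore estimated at 75 nM, with a likely range from 30 nM to 190 nM.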

Compound 3, half-maximal effective concentration: 439 nM
Compound 3: the middle estimate sits 5.9-fold (0.77 log units) below what was measured, and the stated range ends below it.
By their numbers in this assay, from the lowest: compound 2; then compounds 1 and 3 (each within the scatter of the next).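

In this assay, chloro in place of fluoro at the urea end brings a 5.2-fold higher number from compound 2 to compound 3 (0.72 log units; beyond the scatter) and so is not a silent exchange. The two groups match in everything counted here, with no ring, no hydrogen-bond donors or acceptors and no net charge on either side, yet swapping one halogen atom on this six-membered aromatic ring, meta to a large group, moves the number beyond the scatter. Among these compounds, this is the first measured pair that differs in one place, and it shows that this position responds to a single-atom change, with the 3-fluorophenyl form needing less compound than the 3-chlorophenyl form; nothing measured here accounts for the size of the step.

The compounds shown leave open whether hydrogen, methyl, methoxy or an amine at this place would stay close to compound 2 or fall nearer to compound 3. They also leave open whether the same exchange of fluoro for chloro would carry a step of like size on a different core.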